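Exchanging the dichlorophenyl for a fluorophenyl on sulfur

A few compounds are considered here, and "the series" means these few. Any claim that something is new, unique, unknown or untested is made for them only; others in the source may bear on it.

Compound 1, `Nc1cc(N)c2nc(-c3ccccc3)c(Oc3ccc(Cl)c(Cl)c3)nc2c1`, in a functional assay on UACC-62 cells (Homo sapiens) for inhibition, read by sulforhodamine B assay, with a stated time of 48 h (on this read-out higher numbers stand for lower toxicity in this test and lower numbers for higher toxicity in this test), gives < 100000 nM, which is a limit of the assay rather than a number.
Compound 2, `COc1ccc(Sc2nc3cc(N)cc(N)c3nc2-c2ccccc2)cc1`, gives < 100000 nM, again only a limit.
Compound 3, `Nc1cc(N)c2nc(-c3ccccc3)c(Sc3ccc(Cl)c(Cl)c3)nc2c1`, gives < 100000 nM, also a limit.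

Compound 3 therefore has no measured number of its own; it sits at the same limit as the two other compounds, as summed up in the limit of < 100000 nM in this assay, at which 3 of the 3 values shown sit. Compound 4, `Nc1cc(N)c2nc(-c3ccccc3)c(Sc3ccc(F)cc3)nc2c1`, differs from compound 3 in one place: 4-fluorophenyl in place of 3,4-dichlorophenyl on a sulfur.

Among the measured compounds shown here, two measured steps touch the same position. The change from the methoxyphenyl to the dichlorophenyl on sulfur, a step that the two limits leave unreadable from compound 2 to compound 3, and the change from the phenoxy to the phenylsulfanyl link, a step that the two limits leave unreadable from compound 1 to compound 3, both join two limits and so show no readable size. The step from compound 1 to compound 2, a step that the two limits leave unreadable from compound 1 to compound 2, is unreadable for the same reason. For the measured compounds named here, no measured number sets a direction for the step from compound 3 to compound 4, and since every value so far sits at the limit, compound 4 is expected to stay near it as well, with the step that the limit leaves unreadable from compound 3 to compound 4 regarded as an estimate without measured footing. Compound 4 is thus estimated at 40000 nM, within 5000 nM to 100000 nM, and most likely reported again only as a limit.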

Compound 4, concentration lethal to 50% of the cells: 60300 nM
Beside the measured number, compound 4's estimate is 1.5-fold (0.18 log units) below it, and the stated range covers the measured number.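

Compound 4 now has a measured number in this assay, but the steps to it from compound 1, compound 2 and compound 3 cannot be read, because those three compounds each give only a limit of the assay: the limit of < 100000 nM in this assay, at which 3 of the 4 values shown sit.

The compounds shown leave open how much any of these changes shifts the lethal concentration, or in which direction.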